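The source may report more compounds than this note shows. Statements on the series, on what has been measured and on what is new or still open speak of the compounds shown alone.

In an ADME assay on BHK-21 cells (Mesocricetus auratus) for cytotoxicity, read by MTT assay, with a stated time of 72 h (on this read-out higher numbers stand for lower toxicity in this test and lower numbers for higher toxicity in this test), compound 1 `FC(F)(F)c1ccc(NCc2cn(-c3ccccc3)nc2-c2ccc(Br)cc2)cc1` gives 20000 nM, and compound 2 `FC(F)(F)c1ccc(NCc2cn(-c3ccccc3)nc2-c2ccccc2)cc1` gives 37000 nM. These two numbers lie within the usual scatter of each other, so compound 2 cannot be ranked against compound 1. Compound 3 `FC(F)(F)c1ccc(NCc2cn(-c3ccccc3)nc2-c2ccc(Cl)cc2)cc1` keeps the shared core of compound 2 and carries a single change: chloro in place of hydrogen on an aromatic carbon. In words, this is chloro in place of hydrogen on an aromatic carbon, turning phenyl into 4-chlorophenyl. Among the compounds with values here, only one measured step bears on this change: a 1.9-fold higher number from compound 1 to compound 2 (0.27 log units; within the scatter), which swaps bromo, another halogen, for hydrogen. That step stays within the scatter, so no step beyond the scatter is expected in this assay here. The expected step is a 1.5-fold lower number from compound 2 to compound 3 (0.17 log units; within the scatter), which is no real change. For compound 3 the estimate is 25000 nM, with an expected range from 12000 nM to 50000 nM.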

Compound 3, half-maximal cytotoxic concentration: 17000 nM
For compound 3 the middle estimate is 1.5-fold (0.17 log units) above the measured one; the range from low to high includes it.
By their numbers in this assay, from the lowest: compounds 3, 1 and 2 (each within the scatter of the next, the first and the last beyond it).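

Turning phenyl into 4-chlorophenyl gives the first step in this assay that clears the scatter: a 2.2-fold lower number from compound 2 to compound 3 (0.34 log units; beyond the scatter), a modest move towards higher toxicity in this test. Swapping one halogen for the other at this place gives a 1.2-fold lower number from compound 1 to compound 3 (0.07 log units; within the scatter), so compound 1 and compound 3 cannot be ranked against each other, and bromo and chloro read alike here. Nothing measured alongside these numbers explains why chloro in place of hydrogen shifts the number.

The compounds shown leave open whether a group that is not a halogen at this place, such as methoxy, an amine or a carboxylic acid, would shift the number in either direction. They also leave open whether a change on another part of the shared core would matter more than this one.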